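The source may hold more compounds than are shown below. What is called first, only, known or untested is meant among the compounds shown, and "the series" means these compounds.

The series is followed in an assay for inhibition of Thromboxane-A synthase (Homo sapiens), using microsomes; a higher number here means a weaker inhibitor, a lower number a stronger inhibitor. Compound 1 `O=C(O)CC/C=C\CC1COC(c2cccnc2)OC1c1cccnc1` gives 220 nM in this assay. Among the compounds with values here, compound 2 `Cc1ccc(C#N)c(OC(C)(C)C2OCC(C/C=C\CCC(=O)O)C(c3cccnc3)O2)c1` gives 50 nM in this assay, the lowest of the two numbers so far; its nearest neighbour, compound 1, stands at a higher number, and the gap between the two values lies beyond the scatter of repeated measurements. Within the data shown here, the two compounds differ in more than one place, so no single step between them is counted.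

Compound 3 `CSc1ccccc1OC(C)(C)C1OCC(C/C=C\CCC(=O)O)C(c2cccnc2)O1` has not yet been measured. It differs from compound 2 by 2-(methylsulfanyl)phenyl in place of 2-cyano-5-methylphenyl on an oxygen on a saturated carbon. Among the measured compounds shown here, no step between measured compounds shows how such a change moves the number. The step expected here, a 1.4-fold higher number from compound 2 to compound 3 (0.15 log units; within the scatter), is therefore estimated to be small, within or only just beyond the scatter, in either direction. For compound 3 the estimated value in this assay is 70 nM, with a range from 20 nM to 250 nM.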

Compound 3, half-maximal inhibitory concentration: 36 nM
The estimate for compound 3 lay 1.9-fold (0.29 log units) above the measured number; the measured number falls inside the stated range.
By their numbers in this assay, from the lowest: compounds 3 and 2 (each within the scatter of the next); then compound 1.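

Within the data shown here, on the oxygen on a saturated carbon, 2-(methylsulfanyl)phenyl in place of 2-cyano-5-methylphenyl gives a 1.4-fold lower number from compound 2 to compound 3 (0.14 log units; within the scatter) in this assay, the first step that can be read at this position. It shows that a ring carrying a nitrile and a methyl group and a ring carrying a methylsulfanyl group, with their different atoms and the loss of the triple bond, give numbers that cannot be told apart in this assay. Nothing measured on these compounds offers a reason for this.

The compounds shown leave open whether a plain phenyl, or a ring carrying only the nitrile or only the methyl group, would also stay within the scatter of these two. Also open, going by these compounds, is how a phenyl ring carrying an amine or a carboxylic acid would read at this position.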